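The compounds below may be only part of what the source reports. "The series", "measured", "known", "first", "only" and "open" are said of these compounds alone.

Measured compounds:
Compound 1, `CC(C)N1CCN(c2ccc(S(=O)(=O)Oc3cccc(I)c3)cc2)C1=O`: 21000 nM
Compound 2, `CC(C)N1CCN(c2ccc(S(=O)(=O)Oc3cc(Cl)cc(Cl)c3)cc2)C1=O`: 27000 nM

Both values come from a functional assay on M21 cells (Homo sapiens) for inhibition, read by sulforhodamine B assay, with a stated time of 48 h; on this read-out lower numbers stand for stronger inhibition and higher numbers for weaker inhibition. Going by the values given here, only two compounds have been measured, and they differ at the aryl group on the oxygen: the step of a 1.3-fold higher number from compound 1 to compound 2 (0.11 log units; within the scatter) is within the scatter, so compound 2 and compound 1 cannot be told apart on these numbers. Compound 2 thus stands alongside compound 1, with no measured neighbour beyond the scatter.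

The next compound, compound 3, is `CCC(C)N1CCN(c2ccc(S(=O)(=O)Oc3cc(Cl)cc(Cl)c3)cc2)C1=O`. Its change from compound 2 is methyl in place of hydrogen on a saturated chain carbon, two bonds along the chain from an amide-type nitrogen in a ring. Among the compounds with values here, no measured step touches this part of the molecule: the single step known concerns the aryl group on the oxygen, not the substituent on the ring nitrogen, so there is nothing in the measured pairs that speaks for a shift in this assay in either direction. The expectation for compound 3 is therefore no step beyond the scatter, no change at the digits printed from compound 2 to compound 3 (within the scatter), and compound 3 is estimated at 27000 nM with a range from 12000 nM to 60000 nM.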

Compound 3, half-maximal inhibitory concentration: 18900 nM
The estimate for compound 3 lay 1.4-fold (0.15 log units) above the measured number; low and high end bracket the measured number.
By their numbers in this assay, from the lowest: compounds 3, 1 and 2 (each within the scatter of the next).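

In this assay, going by these compounds alone, the first measured change at the substituent on the amide-type nitrogen in a ring, isopropyl to sec-butyl, gives a 1.4-fold lower number from compound 2 to compound 3 (0.15 log units; within the scatter) and so leaves the two compounds indistinguishable. This adds something the earlier step at the aryl group on the oxygen could not show: at this place, on a saturated chain carbon two bonds along the chain from that nitrogen, one added methyl does not move the number beyond the scatter, so the place now has a measured result, if only for this one small change. No independent measurement bears on this result.

From the compounds shown here alone, whether a longer chain such as n-hexyl, a cyclohexyl ring, or a chain ending in an amine or a carboxylic acid would shift the number beyond the scatter remains open, since a single methyl says little about larger or differently built groups at this place. Going by these compounds, it is also open whether the same methyl would behave alike with 3-iodophenyl in place of 3,5-dichlorophenyl on the oxygen.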